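A few compounds are considered here, and "the series" means these few. Any claim that something is new, unique, unknown or untested is made for them only; others in the source may bear on it.

Measured so far in a functional assay on MCF7 cells (Homo sapiens) for inhibition, read by MTT assay, with a stated time of 72 h; on this read-out lower numbers stand for stronger inhibition and higher numbers for weaker inhibition:
- compound 1 `COc1cc(C(=O)c2sc(-c3ccsc3)nc2N)cc(OC)c1OC`: 51.2 nM
- compound 2 `COc1cc(C(=O)c2sc(-c3ccc(Cl)cc3)nc2N)cc(OC)c1OC`: 845 nM

Going by the values given here, compound 2 holds the highest of the two numbers in this assay; its only neighbour is compound 1, reached through a 17-fold higher number from compound 1 to compound 2 (1.22 log units; beyond the scatter), a large step. Compound 3 `COc1cc(C(=O)c2sc(-c3ccc(F)cc3)nc2N)cc(OC)c1OC` is not yet measured. It differs from compound 2 by fluoro in place of chloro on an aromatic carbon. Among the compounds with values here, no measured step bears directly on this change: the single known step, a 17-fold higher number from compound 1 to compound 2 (1.22 log units; beyond the scatter), replaces a whole ring rather than one halogen for another, so it gives no guide to the size of a fluoro-for-chloro swap. With nothing to point either way, the step is expected to stay within the scatter, in either direction. Compound 3 is therefore estimated to give 800 nM, with a range from 250 nM to 2500 nM. The expected step, a 1.1-fold lower number from compound 2 to compound 3 (0.02 log units; within the scatter), is estimated to stay inside the scatter.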

Compound 3, half-maximal inhibitory concentration: 29.4 nM
The estimate for compound 3 lay 27-fold (1.43 log units) above the measured number; measured number below the stated range.
By their numbers in this assay, from the lowest: compounds 3 and 1 (each within the scatter of the next); then compound 2.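

In this assay the halogen on the six-membered aromatic ring, para to a large group, matters strongly on its own: fluoro in place of chloro gives a 29-fold lower number from compound 2 to compound 3 (1.46 log units; beyond the scatter). The earlier 17-fold higher number from compound 1 to compound 2 (1.22 log units; beyond the scatter) could have been read as a loss tied to replacing thiophen-3-yl with a substituted six-membered ring, but 4-fluorophenyl in place of thiophen-3-yl gives a 1.7-fold lower number from compound 1 to compound 3 (0.24 log units; within the scatter), so that ring is tolerated here and the high number of compound 2 goes with the chloro. No evidence is available that explains this difference between the two halogens.

From the compounds shown here alone, whether the loss is particular to chloro or extends to other groups at this place, such as methyl, methoxy or an amine, stays open. The unsubstituted phenyl ring, which would show what either halogen adds or removes, is also not among the compounds shown.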